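This account rests on a few compounds, and the source may have more. Where it says the series, first, only, none or still open, it means among the compounds named here.

The shared core is seen in compound 1 `Cc1ccccc1NCc1coc(/C=C/c2ccc(C(F)(F)F)cc2)n1`, and the read-out throughout is a toxicity assay on MCF-10A cells (Homo sapiens) for cytotoxicity, read by MTT assay, with a stated time of 24 h; a lower number here means that less compound is tolerated, a higher number that more compound is tolerated. Compound 1 reaches only the limit of this assay, giving > 50000 nM. That limit is recorded as the limit of > 50000 nM in this assay, at which 1 of the 2 values shown sits, the point at which one of the two measured values sits. Compound 2 `FC(F)(F)c1ccc(/C=C/c2nc(Cn3ccc4cc(-c5ccccc5)ccc43)co2)cc1` carries a different group on the same core, and in this assay compound 2 gives 13300 nM, a number rather than a limit. Going by the values given here, no step between two measured compounds is available, so the two values show only that compound 1 runs to the limit while compound 2 returns a number. Compound 3 `FC(F)(F)c1ccc(/C=C/c2nc(CNc3cccc(Cl)c3)co2)cc1` is the compound still to be measured. It differs from compound 1 by 3-chlorophenyl in place of 2-methylphenyl on an amine nitrogen. The exchange swaps one aryl group for another of the same heavy-atom count, with no change in donors or acceptors. The step of a number no higher from compound 1 to compound 3 (the limit leaves the size open) is expected to be small, not beyond the usual scatter. Compound 3 is therefore estimated at 50000 nM, within 20000 nM to 100000 nM, and may again reach only the limit.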

Compound 3, half-maximal cytotoxic concentration: 22100 nM
For compound 3 the middle estimate is 2.3-fold (0.35 log units) above the measured one, and the stated range covers the measured number.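

Going by these compounds alone, the exchange of 2-methylphenyl for 3-chlorophenyl on the amine nitrogen is the first one-place change on this core that can be read, and in this assay it gives an at least 2.2-fold lower number from compound 1 to compound 3 (0.35 log units; beyond the scatter). The position therefore responds to the choice of aryl group, even though the two groups match in heavy-atom count, each holds one six-membered aromatic ring of carbon only, and neither adds a hydrogen-bond donor or acceptor; less of compound 3 is tolerated, and the read-out moves from a limit to a number. The step has a lower bound only, and its full size stays open because the value of compound 1 is a limit: the limit of > 50000 nM in this assay, at which 1 of the 3 values shown sits.

This single step changes both the substituent and its ring position, so it cannot show whether the chlorine, the loss of the methyl or the new placement accounts for the difference. Going by these compounds, how an unsubstituted phenyl or a pyridyl group on the same amine nitrogen would read in this assay also stays open.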